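This account rests on a few compounds, and the source may have more. Where it says the series, first, only, none or still open, it means among the compounds named here.

Measured so far:
compound 1, `CC1=C(C(=O)OC(C)(C)C)C(c2cccs2)NC(=O)N1`, 26%
compound 2, `CC1=C(C(=O)OC(C)(C)C)C(c2ccoc2)NC(=O)N1C`, 21%
compound 3, `CC1=C(C(=O)OCC(C)C)C(c2cccs2)NC(=O)N1C`, 9%

All three were tested in an assay on membranes from CHO cells for displacement of a labelled ligand from adenosine receptor A1 (Homo sapiens), read by scintillation counting, with a stated time of 60 min, tested at 1 uM; a higher number here means more inhibition at the concentration tested (going by the name of the read-out), a lower number less inhibition. In this assay compound 1 gives 26%, compound 2 gives 21%, and compound 3 gives 9%, the lowest of the three numbers. The gap from compound 3 to compound 2 lies beyond the scatter, and the gap from compound 3 to compound 1 is larger still.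

Compound 4, `CC1=C(C(=O)OC(C)(C)C)C(c2cccs2)NC(=O)N1C`, has not been measured. It differs from compound 3 in one place: tert-butyl in place of isobutyl on an oxygen next to a carbonyl group. The two have the same atoms, joined differently, with tert-butyl entering where isobutyl leaves.

Within the data shown here, no pair of the measured compounds differs in exactly this way, so the size of the step must be guessed from what the numbers show. Compounds 1 and 2 both carry the tert-butyl group and both sit higher than compound 3, so an upward step beyond the scatter is expected, a number 11 percentage points higher from compound 3 to compound 4 (beyond the scatter). Compound 4 is therefore expected to give about 20% in this assay, within a range from 5% to 35%.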

Compound 4, a percentage reported as inhibition, at one concentration (the size of the read-out at that concentration, not a potency): 18%
The estimate for compound 4 lay 2 percentage points above the measured number; low and high end bracket the measured number.
By their numbers in this assay, from the lowest: compounds 3, 4, 2 and 1 (each within the scatter of the next, the first and the last beyond it).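

In this assay, among these compounds, tert-butyl in place of isobutyl on an oxygen next to a carbonyl group gives a number 9 percentage points higher from compound 3 to compound 4 (within the scatter), so at this position, swapping one of these groups for the other, with the same atoms joined differently, produces no step that stands clear of the usual scatter. The two other single changes also stay within it: thiophen-2-yl in place of furan-3-yl on a saturated ring carbon gives a number 3 percentage points lower from compound 2 to compound 4 (within the scatter), and methyl in place of hydrogen on an amide-type nitrogen in a ring gives a number 8 percentage points lower from compound 1 to compound 4 (within the scatter). Nothing in the data accounts for these small steps.

As far as these compounds go, it remains open whether a longer chain on that oxygen, or a carboxylic acid in place of the ester, would shift the number beyond the scatter. The same question stands for an amine on the ring carbon that now carries the thiophen-2-yl group.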